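Dihydropyridine esters: from a propargyl chain to dinitrophenyl

This account rests on a few compounds, and the source may have more. Where it says the series, first, only, none or still open, it means among the compounds named here.

Compound 1 `CCOC(=O)C1=C(C)NC(COC)=C(C(=O)OC)C1c1cccc([N+](=O)[O-])c1`: 14 nM
Compound 2 `CCOC(=O)C1=C(C)NC(COC(C)=O)=C(C(=O)OCC)C1c1cccc([N+](=O)[O-])c1`: 10 nM
Compound 3 `C#CCCOC(=O)C1=C(C)NC(C)=C(C(=O)OC)C1c1cccc([N+](=O)[O-])c1`: 31 nM

Of the compounds shown here, three sharing one core have been tested in a functional assay on HEK293 cells for antagonist activity at Voltage-dependent L-type calcium channel subunit alpha-1C (Oryctolagus cuniculus), read by FLIPR; on this read-out higher numbers stand for weaker inhibition and lower numbers for stronger inhibition. Compound 1 gives 14 nM and compound 2 gives 10 nM; these two lie within the scatter of each other, so no order between them can be claimed. Compound 3 gives 31 nM, the highest of the three numbers. Its nearest neighbour is compound 1, and the gap to it is beyond the scatter, as is the larger gap to compound 2. Compound 3 is thus the weakest inhibitor of the set in this assay.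

Compound 4 `COC(=O)C1=C(C)NC(C)=C(C(=O)OCc2cc([N+](=O)[O-])cc([N+](=O)[O-])c2)C1c1cccc([N+](=O)[O-])c1` has not yet been measured. It differs from compound 3 in one place: 3,5-dinitrophenyl in place of propargyl on a saturated chain carbon bound to an oxygen next to a carbonyl group. Within the data shown here, no pair among the measured compounds changes this ester group alone, so there is no measured step to lean on. Among the measured compounds shown here, the group that enters is far larger than the one that leaves and carries two nitro groups, and the only guidance is that compound 3, with its propargyl chain, stands at the weak end of the series.

The expectation for compound 4 is a modest move to a lower number, of the size a 1.6-fold lower number from compound 3 to compound 4 (0.19 log units; within the scatter), which may well fall inside the scatter. Compound 4 is therefore estimated at 20 nM, with a range from 5 nM to 80 nM.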

Compound 4, half-maximal inhibitory concentration: 55 nM
For compound 4 the middle estimate is 2.8-fold (0.44 log units) below the measured one, within the range that was stated.
By their numbers in this assay, from the lowest: compounds 2 and 1 (each within the scatter of the next); then compounds 3 and 4 (each within the scatter of the next).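

At this ester position, compound 3 and compound 4 cannot be told apart in this assay: exchanging propargyl for 3,5-dinitrophenyl on a saturated chain carbon bound to an oxygen next to a carbonyl group gives a 1.8-fold higher number from compound 3 to compound 4 (0.25 log units; within the scatter). The earlier compounds shown here offered no step at this place, and this one shows that a group with a six-membered aromatic ring and hydrogen-bond acceptors, which propargyl lacks, can enter without a change that can be read beyond the scatter. The data shown offer no independent measurement that could account for this result.

A single step cannot separate the contribution of the aromatic ring from that of its two nitro groups, so a plain phenyl or a mononitrophenyl in the same place would be needed to tell them apart. On these data alone, whether the position accepts equally an amine or a carboxylic acid at the end of the chain, or a longer chain, remains open, as does whether the same exchange would give a similar step on a core carrying the other substituents of compound 1 or compound 2.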